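The compounds below may be only part of what the source reports. "The series", "measured", "known", "first", "only" and "open" are said of these compounds alone.

Compound 3, `CNC1CCN(c2ccc3[nH]nc(-c4cnn(C)c4)c3c2)C1`, stands at the top of the three numbers gathered in an assay on isolated protein for inhibition of tyrosine-protein kinase receptor UFO (Homo sapiens), with a stated time of 1.5 h; a higher number here means a weaker inhibitor, a lower number a stronger inhibitor: compound 3 gives 432000 nM, the highest of the set. Going by the values given here, its nearest neighbour is compound 1, `Cn1cc(-c2n[nH]c3ccc(NC4CCNC4)cc23)cn1`, which gives 132000 nM; the single measured step, a 3.3-fold higher number from compound 1 to compound 3 (0.51 log units; beyond the scatter), introduced 3-(methylamino)pyrrolidin-1-yl in place of (pyrrolidin-3-yl)amino on an aromatic carbon. Furthest away is compound 2, `Nc1ccc2c(-c3cccnc3)n[nH]c2c1`, which carries a plain amino group and gives 28400 nM.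

The next compound, compound 4, `Cn1cc(-c2n[nH]c3ccc(N)cc23)cn1`, strips the ring substituent down: amino in place of 3-(methylamino)pyrrolidin-1-yl on an aromatic carbon. Among the compounds with values here, no measured step covers exactly this change, so the only guide is that compound 2, the one compound bearing an amino group, holds the lowest number, while both ring-bearing compounds sit far higher. On that basis a sizeable drop is expected, an 11-fold lower number from compound 3 to compound 4 (1.03 log units; beyond the scatter), bringing compound 4 towards the region of compound 2 while the different aromatic partner keeps the estimate broad. Compound 4 is therefore estimated at 40000 nM, expected to fall between 10000 nM and 160000 nM.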

Compound 4, half-maximal inhibitory concentration: 8910 nM
Beside the measured number, compound 4's estimate is 4.5-fold (0.65 log units) above it; the measured number lies below the stated range.
By their numbers in this assay, from the lowest: compound 4; then compound 2; then compound 1; then compound 3.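

On the shared core of compounds 1, 3 and 4, the group on this aromatic carbon now spans a plain amino group and two pyrrolidine-bearing groups: in this assay, amino in place of 3-(methylamino)pyrrolidin-1-yl gives a 48-fold lower number from compound 3 to compound 4 (1.69 log units; beyond the scatter), and hydrogen in place of pyrrolidin-3-yl on the nitrogen gives a 15-fold lower number from compound 1 to compound 4 (1.17 log units; beyond the scatter). Both steps are larger than the earlier one between the two ring-bearing compounds, a 3.3-fold higher number from compound 1 to compound 3 (0.51 log units; beyond the scatter), so on this core the presence of the pyrrolidine ring goes with a larger shift in the number than the way it is attached. The data offer no evidence on what lies behind this shift.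

On these data alone, whether a methylamino group or an acetamide on this carbon would lower the number further remains open. So does whether an open-chain amine, such as a 2-aminoethylamino group, would track the plain amino group or the pyrrolidine-bearing compounds.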